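Ethyl to Propyl on a Core Without Measured Cytotoxicity

This account rests on a few compounds, and the source may have more. Where it says the series, first, only, none or still open, it means among the compounds named here.

Compound 1 `CCc1ccc(-c2nc3c(c(C)nn3-c3ccccc3)c(-c3ccccc3O)c2C#N)cc1`: > 20000 nM
Compound 2 `CCc1ccc(-c2nc3c(c(C)nn3-c3ccccc3)c(-c3ccccc3I)c2C#N)cc1`: > 20000 nM
Compound 3 `CCc1ccc(-c2nc3c(c(C)nn3-c3ccccc3)c(-c3ccccc3S(C)(=O)=O)c2C#N)cc1`: > 20000 nM

In an ADME assay on BJ cells (Homo sapiens) for cytotoxicity, with a stated time of 72 h (a higher number here means that more compound is needed for the effect, a lower number that less compound is needed), compound 1 stands at a limit of the assay rather than at a number. Compound 2 and compound 3 each also stand at a limit, so the steps a step that the two limits leave unreadable from compound 1 to compound 2, a step that the two limits leave unreadable from compound 1 to compound 3 and a step that the two limits leave unreadable from compound 2 to compound 3 cannot be read; all that is shown is the limit of > 20000 nM in this assay, at which 3 of the 3 values shown sit. The change to compound 4 `CCCc1ccc(-c2nc3c(c(C)nn3-c3ccccc3)c(-c3ccccc3O)c2C#N)cc1` is methyl in place of hydrogen on a saturated chain carbon, two bonds along the chain from an aromatic carbon. Among the compounds with values here, no measured step bears on this change, and none of the three compounds gives a number to work from, so nothing beyond the scatter is expected in this assay . Compound 4 is therefore estimated at 30000 nM, within 15000 nM to 100000 nM, most likely reported again only as a limit. The expected step is a step that the limit leaves unreadable from compound 1 to compound 4.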

Compound 4, half-maximal effective concentration: 22500 nM
For compound 4 the middle estimate is 1.3-fold (0.12 log units) above the measured one; the range from low to high includes it.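

No step can be read from compound 1 to compound 4: compound 1 stands only at a limit. The compounds shown leave open what ethyl to propyl does in this assay, and whether compound 1, compound 2 and compound 3 differ at all.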